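Swapping a pyridine for an isothiazole on the aryl tail

This account rests on a few compounds, and the source may have more. Where it says the series, first, only, none or still open, it means among the compounds named here.

Measured compounds:
- compound 1, `CCC(C)(C)Cc1c[nH]c(CCc2ccc(-c3cnccn3)cc2)n1`: 107 nM
- compound 2, `CCC(C)(C)Cc1c[nH]c(CCc2ccc(-c3ccccc3C(=O)O)cc2)n1`: 94 nM
- compound 3, `CCC(C)(C)Cc1c[nH]c(CCc2ccc(-c3cccnc3)cc2)n1`: 97 nM

These three share one core and differ only in the ring attached para to the large group. In a functional assay on HEK293 cells for agonist activity at Bombesin receptor subtype-3 (Mus musculus), read by luminescence and calcium flux, with a stated time of 10 min (a lower number here means that less compound is needed, a higher number that more compound is needed for the effect), compound 3 gives 97 nM, second highest of the three, yet all three numbers sit within the scatter of one another: a 1.1-fold lower number from compound 1 to compound 3 (0.04 log units; within the scatter), a 1.1-fold lower number from compound 1 to compound 2 (0.06 log units; within the scatter) and a 1.0-fold higher number from compound 2 to compound 3 (0.01 log units; within the scatter).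

Compound 4, `CCC(C)(C)Cc1c[nH]c(CCc2ccc(-c3ccns3)cc2)n1`, continues this series with 1,2-thiazol-5-yl in place of pyridin-3-yl on an aromatic carbon. For the measured compounds named here, every step at this position so far has stayed within the scatter, so another change of ring here is expected to give no step beyond it in this assay. Compound 4 is therefore estimated at 100 nM, in the range 45 nM to 220 nM, a step of a 1.0-fold higher number from compound 3 to compound 4 (0.01 log units; within the scatter).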

Compound 4, half-maximal effective concentration: 103 nM
Beside the measured number, compound 4's estimate is 1.0-fold (0.01 log units) below it; low and high end bracket the measured number.
By their numbers in this assay, from the lowest: compounds 2, 3, 4 and 1 (each within the scatter of the next).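

For the compounds shown here, for the first time the ring at this place is five-membered and carries sulfur, and in this assay the result still stays within the scatter: a 1.1-fold higher number from compound 3 to compound 4 (0.03 log units; within the scatter) and a 1.1-fold higher number from compound 2 to compound 4 (0.04 log units; within the scatter) and also a 1.0-fold lower number from compound 1 to compound 4 (0.02 log units; within the scatter) in this set. Across these four compounds, then, neither ring size nor the swap of hetero atoms gives a step beyond the scatter. No measurement shown here explains this. 
Still open, as far as these compounds go, is whether a saturated piperidine ring, or an amine on the aromatic ring, would also stay within the scatter.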